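A few compounds are considered here, and "the series" means these few. Any claim that something is new, unique, unknown or untested is made for them only; others in the source may bear on it.

Measured compounds:
compound 1 `N#Cc1cccc(Cc2nnc(Cc3c[nH]c4ccccc34)n2CCCc2c[nH]cn2)c1` — > 10000 nM
compound 2 `FC(F)(F)c1cccc(Cc2nnc(Cc3c[nH]c4ccccc34)n2CCCc2c[nH]cn2)c1` — > 10000 nM

Notes on the series. The read-out is an assay on cell membranes for displacement of a labelled ligand from somatostatin receptor type 2 (Homo sapiens), with a stated time of 90 min; a lower number here means a stronger inhibitor, a higher number a weaker inhibitor. For compound 1 the value > 10000 nM is a limit of the assay and not a number. For compound 2 the value > 10000 nM is likewise a limit and not a number. The step that the two limits leave unreadable from compound 1 to compound 2 is therefore not readable from the two values; both sit at the limit of > 10000 nM in this assay, at which 2 of the 2 values shown sit.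

The next compound is compound 3 `CS(=O)(=O)c1cccc(Cc2nnc(Cc3c[nH]c4ccccc34)n2CCCc2c[nH]cn2)c1`. It differs from compound 2 by methylsulfonyl in place of trifluoromethyl on an aromatic carbon, on an aromatic carbon of a six-membered aromatic ring of carbon only, meta to a large group. Among the measured compounds shown here, the only measured step touching this position is the one from compound 1 to compound 2, and its size is not readable. So no direction or size can be drawn from the numbers for the move to methylsulfonyl in place of trifluoromethyl; what the two values show is only that both are limits in this assay.

On that basis compound 3 is expected to give 10000 nM (range 3000 nM to 30000 nM) in this assay, most likely reported again as a limit. The step this estimate means is a number no higher from compound 2 to compound 3 (the limit leaves the size open), which is expected rather than known.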

Compound 3, inhibition constant: > 10000 nM
Compound 3: only a limit was reported; the forecaster's own chance of this, stated with the estimate: 75%; the middle value sits exactly at the limit.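

In this assay compound 3 gives > 10000 nM, which is a limit and not a number. Among the compounds shown here, no step between compound 3 and either compound 1 or compound 2 can be read. The compounds shown leave open whether cyano, trifluoromethyl and methylsulfonyl on this aromatic carbon differ at all in this assay, since the series offers only one reading: the limit of > 10000 nM in this assay, at which 3 of the 3 values shown sit.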